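A few compounds are considered here, and "the series" means these few. Any claim that something is new, unique, unknown or untested is made for them only; others in the source may bear on it.

Measured compounds in a functional assay on SN12C cells (Homo sapiens) for cytotoxicity, read by sulforhodamine B assay, with a stated time of 48 h; on this read-out lower numbers stand for higher toxicity in this test and higher numbers for lower toxicity in this test:
compound 1 `ClCc1cccc(Cn2cnc3c(Cl)nc(Cl)nc32)c1` gives 11800 nM
compound 2 `Nc1nc(Cl)c2ncn(Cc3ccccc3CCl)c2n1` gives 19500 nM
compound 3 `ClCc1cccc(Cn2cnc3nc(Cl)nc(Cl)c32)c1` gives "not determined" (no result reported)

Compound 2 holds the highest of the two available numbers; the nearest is compound 1, and the gap between the two lies within the usual scatter, so no order between them can be read. Compound 3 contributes no number.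

Compound 4 `ClCc1ccccc1Cn1cnc2c(Cl)ncnc21` has not yet been tested in this assay. Against compound 2 the change is hydrogen in place of amino on an aromatic carbon. Among the compounds with values here, no pair of measured compounds differing in one place exists in this set, so the size of such a step is not known from the data. A step no larger than the scatter is expected, without a clear direction. Compound 4 is expected to give 16000 nM, with a range from 5000 nM to 50000 nM. This amounts to an expected step of a 1.2-fold lower number from compound 2 to compound 4 (0.09 log units; within the scatter).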

Compound 4, concentration lethal to 50% of the cells: 95500 nM
Estimate against measurement, compound 4: 6.0-fold (0.78 log units) below, outside the stated range (above it).
By their numbers in this assay, from the lowest: compounds 1 and 2 (each within the scatter of the next); then compound 4.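

Within the data shown here, putting hydrogen in place of amino on the aromatic carbon between two ring nitrogen atoms gives a 4.9-fold higher number from compound 2 to compound 4 (0.69 log units; beyond the scatter) in this assay, the first step that lies beyond the scatter. Among these compounds, this position therefore matters in this pair: the amino compound shows the higher toxicity in this test, which the earlier compounds could not show. Nothing available explains the step.

As far as these compounds go, whether a methylamino or hydroxyl group on this carbon would stay near compound 2 remains open. A single pair also leaves open whether the step holds on other members of the series.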